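The source may hold more compounds than are shown below. What is called first, only, known or untested is meant among the compounds shown, and "the series" means these compounds.

Measured so far:
- compound 1 `CCOc1ccccc1C[C@H]1COC(=O)[C@@H]1Cc1ccc(Cl)c(Cl)c1`: 31000 nM
- compound 2 `Cc1ccccc1C[C@H]1COC(=O)[C@@H]1Cc1ccc(Cl)c(Cl)c1`: "not determined" (no result reported)

Both compounds were examined in a functional assay on HeLa cells (Homo sapiens) for cytotoxicity, read by WST assay, with a stated time of 48 h (a lower number here means that less compound is needed, a higher number that more compound is needed for the effect), but only compound 1 has a number there, at 31000 nM. Going by the values given here, compound 2 therefore has no standing on the numbers, and no measured step connects it to anything else. Compound 3 `O=C1OC[C@H](Cc2cccc(F)c2)[C@H]1Cc1ccc(Cl)c(Cl)c1` has still to be measured in this assay. The structural change is 3-fluorophenyl in place of 2-methylphenyl on a saturated chain carbon bound to a saturated ring carbon, which puts 3-fluorophenyl in place of 2-methylphenyl on a saturated chain carbon bound to a saturated ring carbon. Without a value for compound 2, the size of this step cannot be anchored at its starting point. The nearest reference is compound 1 at 31000 nM, and no shift beyond the usual scatter from that level is expected, in either direction. For compound 3 the estimated value is 30000 nM, with an expected range of 12000 nM to 75000 nM.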

Compound 3, half-maximal effective concentration: 20000 nM
Compound 3: the middle estimate sits 1.5-fold (0.18 log units) above what was measured; measured number inside the range.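

Going by these compounds alone, compound 2 has no number in this assay so no step to compound 3 can be read. The compounds shown leave open how 3-fluorophenyl compares with 2-methylphenyl at this place in the shared core. No measured evidence bears on this result.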